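From a Carboxymethylsulfonyl Chain to a Tetrazolyl Chain

The source may hold more compounds than are shown below. What is called first, only, known or untested is meant among the compounds shown, and "the series" means these compounds.

In a functional assay for inhibition, with Homo sapiens as the target (a lower number here means a stronger inhibitor, a higher number a weaker inhibitor), compound 1 `COC(=O)CCCCCCCCn1nc(-c2ccccc2)c(-c2ccccc2)c1-c1ccccc1`, whose chain ends in methoxycarbonyl, gives 4300 nM. Compound 2 `O=C(O)CCCCCCCCCCn1nc(-c2ccccc2)c(-c2ccccc2)c1-c1ccccc1` gives 18600 nM, and compound 3 `O=C(O)CS(=O)(=O)CCCCCCn1nc(-c2ccccc2)c(-c2ccccc2)c1-c1ccccc1` gives 22000 nM. The chains of the last two differ, yet their values stand level, with a 1.2-fold higher number from compound 2 to compound 3 (0.07 log units; within the scatter). Both stand apart from the first, with a 4.3-fold higher number from compound 1 to compound 2 (0.64 log units; beyond the scatter) and a 5.1-fold higher number from compound 1 to compound 3 (0.71 log units; beyond the scatter).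

Compound 4 `c1ccc(-c2nn(CCCCCCCCc3nnn[nH]3)c(-c3ccccc3)c2-c2ccccc2)cc1` has 2-(1H-tetrazol-5-yl)ethyl in place of (carboxymethyl)sulfonyl on a saturated chain carbon, six bonds along the chain from an aromatic nitrogen. Going by the values given here, no measured compound carries this tetrazolyl group, so no step measures the change directly. The closest guide is the chain change in a 1.2-fold higher number from compound 2 to compound 3 (0.07 log units; within the scatter), which suggests little movement, while the two larger steps warn that the end of the chain can matter. No shift beyond the scatter is therefore expected in this assay. The estimated change is a 1.4-fold lower number from compound 3 to compound 4 (0.14 log units; within the scatter). Compound 4 is estimated at 16000 nM, with an expected range from 5000 nM to 45000 nM.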

Compound 4, half-maximal inhibitory concentration: 1040 nM
Estimate against measurement, compound 4: 15-fold (1.19 log units) above, and the stated range ends above it.
By their numbers in this assay, from the lowest: compound 4; then compound 1; then compounds 2 and 3 (each within the scatter of the next).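

In this assay, 2-(1H-tetrazol-5-yl)ethyl in place of (carboxymethyl)sulfonyl brings a 21-fold lower number from compound 3 to compound 4 (1.33 log units; beyond the scatter) at this place on the chain, so the two groups differ sharply in effect even though they match in heavy atoms, hydrogen-bond donors and hydrogen-bond acceptors as counted. The same tetrazolyl chain end also gives an 18-fold lower number from compound 2 to compound 4 (1.25 log units; beyond the scatter) and a 4.1-fold lower number from compound 1 to compound 4 (0.62 log units; beyond the scatter) in place of methoxycarbonyl on the saturated chain. Compound 4 is thus the strongest inhibitor of the four, and a change at the chain end can carry the number well past the level shared by compound 2 and compound 3. Nothing at hand accounts for this gain.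

The compounds shown leave open whether a carboxylic acid on a chain of the same length as in compound 4 would stand nearer compound 4 or compound 2. They also leave open whether a shorter or longer chain ending in 1H-tetrazol-5-yl would hold this value.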